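Replacing the hydroxyphenyl of compound 3 with a methylphenyl

A few compounds are considered here, and "the series" means these few. Any claim that something is new, unique, unknown or untested is made for them only; others in the source may bear on it.

Measured compounds:
Compound 1, `CC(Oc1ccccc1-c1cccnc1)C1=NCCN1`: 64.6 nM
Compound 2, `CC(Oc1ccccc1-c1ccccc1[N+](=O)[O-])C1=NCCN1`: 1230 nM
Compound 3, `CC(Oc1ccccc1-c1ccccc1O)C1=NCCN1`: 1620 nM

All three share the same core and differ only in the aromatic group attached to it. In an assay on CHO cells for displacement of a labelled ligand from Alpha-2C adrenergic receptor (Homo sapiens) (a higher number here means a weaker inhibitor, a lower number a stronger inhibitor), compound 3 gives the highest number of the three, yet its gap to compound 2 is within the usual scatter, so the two cannot be told apart; only compound 1 stands clearly lower, as a 25-fold higher number from compound 1 to compound 3 (1.40 log units; beyond the scatter) shows. The step of a 1.3-fold higher number from compound 2 to compound 3 (0.12 log units; within the scatter) shows that exchanging the hydroxy for a nitro on that ring left the result essentially unchanged.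

Compound 4, `Cc1cccc(-c2ccccc2OC(C)C2=NCCN2)c1`, carries 3-methylphenyl in place of 2-hydroxyphenyl on an aromatic carbon. Within the data shown here, no measured step covers this exact exchange. The step from compound 1 to compound 3 shows that the identity of the attached ring can move this assay by a large amount, while the step from compound 2 to compound 3 shows that at least one swap on that ring barely matters. Since compound 4 removes the group that compounds 2 and 3 both carry, a lower number is expected, with wide uncertainty: compound 4 is expected at 300 nM (range 60 nM to 1500 nM), a step of a 5.4-fold lower number from compound 3 to compound 4 (0.73 log units; beyond the scatter).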

Compound 4, inhibition constant: 245 nM
Estimate against measurement, compound 4: 1.2-fold (0.09 log units) above, within the range that was stated.
By their numbers in this assay, from the lowest: compound 1; then compound 4; then compounds 2 and 3 (each within the scatter of the next).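

In this assay, moving from 2-hydroxyphenyl to 3-methylphenyl shifts the result clearly (a 6.6-fold lower number from compound 3 to compound 4 (0.82 log units; beyond the scatter)), so this position does respond to a change on the attached carbon-only ring, which the swap between hydroxy and nitro did not show. The same ring still falls short of pyridin-3-yl (a 3.8-fold higher number from compound 1 to compound 4 (0.58 log units; beyond the scatter)), which means that 3-methylphenyl recovers only part of the gap between compound 3 and compound 1. Nothing available here explains either step.

This exchange removes a hydroxy and adds a methyl at once, and the two changes cannot be separated with these compounds. Unsubstituted phenyl would give the ring with neither group, while a methoxy or an amine on that ring would test other replacements.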